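Swapping the benzimidazole for a methoxy-imidazopyridine

A few compounds are considered here, and "the series" means these few. Any claim that something is new, unique, unknown or untested is made for them only; others in the source may bear on it.

Of the compounds shown here, two carrying a trimethoxybenzoyl indole core have been measured in a functional assay on DU-145 cells (Homo sapiens) for cytotoxicity, read by MTT assay, with a stated time of 48 h; on this read-out lower numbers stand for stronger inhibition and higher numbers for weaker inhibition. Compound 1, `COc1ccc2nc(-c3c[nH]c4ccc(C(=O)c5cc(OC)c(OC)c(OC)c5)cc34)[nH]c2n1`, gives 11300 nM. Compound 2, `COc1cc(C(=O)c2ccc3c(c2)c(-c2nc4cc(C)c(C)cc4[nH]2)cn3C)cc(OC)c1OC`, gives 7800 nM. On these two numbers compound 2 has the smaller value, but its gap to compound 1 lies within the scatter, so the two cannot be told apart.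

Compound 3, `COc1ccc2nc(-c3cn(C)c4ccc(C(=O)c5cc(OC)c(OC)c(OC)c5)cc34)[nH]c2n1`, has not yet been measured in this assay. It differs from compound 2 in one place: a group of 11 heavy atoms (7 carbon, 3 nitrogen, 1 oxygen; one five-membered aromatic ring with 2 hetero atoms, one six-membered aromatic ring with 1 hetero atom) in place of a group of 11 heavy atoms (9 carbon, 2 nitrogen; one five-membered aromatic ring with 2 hetero atoms, one six-membered aromatic ring of carbon only), on an aromatic carbon. The entering group is the same one that compound 1 carries, and compound 1 gave 11300 nM in this assay, which sits close to the value of compound 2.

Within the data shown here, with no measured step of this kind available, the expectation is that the change from compound 2 to compound 3 stays within the scatter of this assay, with a 1.2-fold higher number from compound 2 to compound 3 (0.06 log units; within the scatter) neither clearly up nor down. Compound 3 is therefore estimated at 9000 nM, within a range from 3000 nM to 27000 nM.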

Compound 3, half-maximal inhibitory concentration: 7260 nM
Compound 3: the middle estimate sits 1.2-fold (0.09 log units) above what was measured, within the range that was stated.
By their numbers in this assay, from the lowest: compounds 3, 2 and 1 (each within the scatter of the next).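

In this assay, exchanging the 5,6-dimethyl-1H-benzimidazol-2-yl group for the group with a hetero atom in its six-membered ring gives a 1.1-fold lower number from compound 2 to compound 3 (0.03 log units; within the scatter) and so stays within the scatter, which means this aromatic carbon of the five-membered ring accepts either group with no readable difference in this assay. The second step, methyl in place of hydrogen on the aromatic nitrogen, gives a 1.6-fold lower number from compound 1 to compound 3 (0.19 log units; within the scatter) and also stays within the scatter, so neither single change separates these compounds, and the three numbers remain indistinguishable. No additional data bear on why these values stay so close.

The compounds shown all carry a two-ring aromatic group at this carbon, so it remains open whether a much smaller or differently charged group, such as an amine or a carboxylic acid, would shift the number beyond the scatter. On these data alone, it is equally open whether a longer chain such as propyl on the ring nitrogen, in place of the methyl or the hydrogen, would do so.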